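Swapping a naphthalene for a trifluoromethylbenzyl group

A few compounds are considered here, and "the series" means these few. Any claim that something is new, unique, unknown or untested is made for them only; others in the source may bear on it.

Of the compounds shown here, three sharing one core have been tested in an ADME assay on HepG2 cells (Homo sapiens) for cytotoxicity, read by luminescence, CellTiter-Glo and ATP content, with a stated time of 72 h; on this read-out lower numbers stand for an effect already at smaller amounts and higher numbers for an effect only at larger amounts of compound. Compound 1 `COc1cccc(CNCCCNc2ccnc3cc(CCC(C)C)ccc23)c1O` gives 5390 nM, compound 2 `COc1cccc(CNCCCNc2ccnc3cc(-c4ccccc4)ccc23)c1O` gives 3210 nM, and compound 3 `COc1cccc(CNCCCNc2ccnc3cc(-c4cccc5ccccc45)ccc23)c1O` gives 2520 nM. Compound 3 thus has the lowest of the three numbers; the step of a 1.3-fold lower number from compound 2 to compound 3 (0.11 log units; within the scatter) lies within the scatter, while the step of a 2.1-fold lower number from compound 1 to compound 3 (0.33 log units; beyond the scatter) is just beyond it.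

Compound 4 `COc1cccc(CNCCCNc2ccnc3cc(Cc4cccc(C(F)(F)F)c4)ccc23)c1O` differs from compound 3 in one place: 3-(trifluoromethyl)benzyl in place of naphthalen-1-yl on an aromatic carbon. Among the measured compounds shown here, the steps that bear on this change all concern the same position. Going from a chain to an aromatic group gave a 1.7-fold lower number from compound 1 to compound 2 (0.23 log units; within the scatter) and a 2.1-fold lower number from compound 1 to compound 3 (0.33 log units; beyond the scatter), and adding a second ring to the aromatic group gave a 1.3-fold lower number from compound 2 to compound 3 (0.11 log units; within the scatter). All three steps are small, and none points to a position that reacts strongly to what sits there. The entering group, one aromatic ring carrying a trifluoromethyl, is expected to behave much like the groups already seen, so for compound 4 in this assay a step of a 1.4-fold higher number from compound 3 to compound 4 (0.14 log units; within the scatter) is estimated, that is, no change beyond the scatter. The number for compound 4 is therefore expected to be 3500 nM, with a range from 1700 nM to 7500 nM.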

Compound 4, half-maximal effective concentration: 1720 nM
For compound 4 the middle estimate is 2.0-fold (0.31 log units) above the measured one; measured number inside the range.
By their numbers in this assay, from the lowest: compounds 4, 3, 2 and 1 (each within the scatter of the next, the first and the last beyond it).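

In this assay, compound 4 cannot be told apart from the compounds carrying naphthalen-1-yl or phenyl, since both steps stay within the scatter (a 1.5-fold lower number from compound 3 to compound 4 (0.17 log units; within the scatter); a 1.9-fold lower number from compound 2 to compound 4 (0.27 log units; within the scatter)). So a 3-(trifluoromethyl)benzyl group, with a single aromatic ring, fits in with the two groups already seen at this aromatic carbon, and the second aromatic ring of naphthalen-1-yl is not needed to reach numbers of this size. The isopentyl compound now shows its largest step at this position (a 3.1-fold lower number from compound 1 to compound 4 (0.50 log units; beyond the scatter)), but the pattern of a lower number with an aromatic group is not uniform, as compound 2 stays within the scatter of compound 1 (a 1.7-fold lower number from compound 1 to compound 2 (0.23 log units; within the scatter)). Nothing measured here explains these numbers.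

From the compounds shown here alone, it remains open how a plain benzyl group would compare with 3-(trifluoromethyl)benzyl, which would show whether the trifluoromethyl contributes anything to the number of compound 4. It is also open whether an amine or a carboxylic acid on this aromatic carbon would shift the number further than any of the groups shown.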